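Growth inhibition notes: compound 1 to compound 3

The compounds below may be only part of what the source reports. "The series", "measured", "known", "first", "only" and "open" are said of these compounds alone.

Measured in a functional assay on NCI-H322M cells (Homo sapiens) for inhibition, read by sulforhodamine B assay, with a stated time of 48 h; on this read-out lower numbers stand for stronger inhibition of growth and higher numbers for weaker inhibition of growth:
- Compound 1 `COc1cc(-c2nn(-c3cccc(NC(=O)c4cccc(C(F)(F)F)c4)c3)cc2-c2ccncc2)ccc1Cl`: > 50000 nM
- Compound 2 `O=C(Nc1cccc(-n2cc(-c3ccncc3)c(-c3ccc(Cl)c(O)c3)n2)c1)Nc1cc(C(F)(F)F)cc(C(F)(F)F)c1`: 5390 nM

Compound 1 stands at > 50000 nM, which is a limit of the assay and not a number. Compound 3 `COc1cc(-c2nn(-c3cccc(NC(=O)Nc4ccc(Cl)c(C(F)(F)F)c4)c3)cc2-c2ccncc2)ccc1Cl` has (4-chloro-3-(trifluoromethyl)phenyl)amino in place of 3-(trifluoromethyl)phenyl on a carbonyl carbon. In this assay a sizeable step toward stronger inhibition is expected, since compound 2 also has a phenylamino group on its carbonyl carbon and gives 5390 nM. Compound 2 differs in other places too, so this support is modest. The expected step is an at least 5.5-fold lower number from compound 1 to compound 3 (0.74 log units; beyond the scatter). The estimate for compound 3 is 9000 nM, with an expected range of 3000 nM to 40000 nM.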

Compound 3, concentration for total growth inhibition: 13900 nM
Estimate against measurement, compound 3: 1.5-fold (0.19 log units) below; low and high end bracket the measured number.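

In this assay, (4-chloro-3-(trifluoromethyl)phenyl)amino in place of 3-(trifluoromethyl)phenyl on a carbonyl carbon gives a readable gain in growth inhibition: an at least 3.5-fold lower number from compound 1 to compound 3 (0.55 log units; beyond the scatter). Compound 1 stands at a limit of the assay and not at a number, so this step has only a lower bound: the limit of > 50000 nM in this assay, at which 1 of the 3 values shown sits. The change brings in a nitrogen and a chlorine together, so the step cannot be assigned to either alone.

Still open, going by these compounds, is how the amino nitrogen reads without the chlorine, and the chlorine without the amino nitrogen. Also open, on these data alone, is whether a cyclohexylamino group on the same carbonyl carbon would keep the gain.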